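What an Isopropyl Group Might Do to Compound 2

This account rests on a few compounds, and the source may have more. Where it says the series, first, only, none or still open, it means among the compounds named here.

In a functional assay (thoracic aorta) for inhibition, with Rattus norvegicus as the target (a lower number here means a stronger inhibitor, a higher number a weaker inhibitor), compound 1 (`O=C(O)c1cc(CCCCNS(=O)(=O)c2ccccc2)c2cccccc1-2`) gives 570 nM and compound 2 (`O=C(O)c1cc(CCCCCNS(=O)(=O)c2ccccc2)c2cccccc1-2`) gives 840 nM, two values within the usual scatter of each other. Compound 3 (`O=C(O)c1cc(CCCCCCCCNS(=O)(=O)c2ccccc2)c2cccccc1-2`) gives 38 nM, a stronger result than compound 2 by more than the scatter. Compound 2 therefore stands level with compound 1 and well above compound 3 on these numbers. Compound 4 (`CC(C)c1ccc2c(CCCCCNS(=O)(=O)c3ccccc3)cc(C(=O)O)c-2cc1`) alters compound 2 in one place (isopropyl in place of hydrogen on an aromatic carbon): isopropyl in place of hydrogen on an aromatic carbon. Within the data shown here, no measured compound carries this group, so the expectation is loose: a small move toward a lower number in this assay, an estimated 1.7-fold lower number from compound 2 to compound 4 (0.23 log units; within the scatter) (none beyond the scatter). For compound 4 the estimated value is 500 nM (expected range 100 nM to 2000 nM).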

Compound 4, half-maximal inhibitory concentration: 120 nM
Compound 4: the middle estimate sits 4.2-fold (0.62 log units) above what was measured; measured number inside the range.
By their numbers in this assay, from the lowest: compound 3; then compound 4; then compounds 1 and 2 (each within the scatter of the next).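

The earlier compounds shown here differ only in the chain, so they say nothing about the seven-membered aromatic ring. In this assay, isopropyl in place of hydrogen on an aromatic carbon of that ring gives a 7.0-fold lower number from compound 2 to compound 4 (0.85 log units; beyond the scatter), so this ring position accepts an added group of carbon only, and the number falls beyond the scatter. Nothing shown here gives a reason for this drop.

Whether the drop belongs to isopropyl itself stays open, since methyl, tert-butyl or fluorine on that carbon are not among these compounds. Also open, as far as these compounds go, is whether isopropyl would lower the number in compound 3 as well.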